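The compounds below may be only part of what the source reports. "The series", "measured", "known", "first", "only" and "open" are said of these compounds alone.

Measured compounds in an ADME assay on MDBK cells (Bos taurus) for cytotoxicity; a lower number here means that less compound is tolerated, a higher number that more compound is tolerated:

compound 1 `COc1ccc(Cn2ccc3nc(-c4ccccc4)nc-3c2)cc1` — > 100000 nM
compound 2 `c1ccc(-c2ccc(Cn3ccc4nc(-c5ccccc5)nc-4c3)cc2)cc1` — 18000 nM
compound 3 `O=C(O)c1ccc(Cn2ccc3nc(-c4ccccc4)nc-3c2)cc1` — > 100000 nM

The value given for compound 1 is a limit of the assay, not a number. Compound 3 likewise gives only a limit. For the measured compounds named here, compound 1 therefore stands at the limit of > 100000 nM in this assay, at which 2 of the 3 values shown sit, with compound 2 the single compound that returns a number.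

Compound 4 `C(=C/c1ccccc1)\Cn1ccc2nc(-c3ccccc3)nc-2c1` differs from compound 1 in one place: 2-phenylethenyl in place of 4-methoxyphenyl on a saturated chain carbon bound to an aromatic nitrogen. The nearest measured step is an at least 5.5-fold lower number from compound 1 to compound 2 (0.74 log units; beyond the scatter), where adding an aromatic ring lowered the tolerated concentration; the reverse, an at least 5.5-fold higher number from compound 2 to compound 3 (0.74 log units; beyond the scatter), went the other way. Compound 4 also carries an added aromatic ring, so a step of similar size and direction is expected, an at least 3.3-fold lower number from compound 1 to compound 4 (0.52 log units; beyond the scatter). Compound 4 is accordingly estimated at 30000 nM, within 10000 nM to 100000 nM.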

Compound 4, half-maximal cytotoxic concentration: 78000 nM
Compound 4: middle estimate off by 2.6-fold (0.41 log units), on the low side; the range from low to high includes it.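

In this assay, 2-phenylethenyl in place of 4-methoxyphenyl at this saturated chain carbon gives an at least 1.2-fold lower number from compound 1 to compound 4 (0.10 log units; that floor lies within the scatter). This change of the whole group therefore brings a measurable value at this position, yet its floor alone shows no change beyond the scatter. Compound 1 gives only a limit, not a number: the limit of > 100000 nM in this assay, at which 2 of the 4 values shown sit.

As far as these compounds go, the size of the true step stays open, as does whether the double bond or the loss of the methoxy oxygen matters more. From the compounds shown here alone, how an amine or a longer saturated chain would behave in this place also remains open.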